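This account rests on a few compounds, and the source may have more. Where it says the series, first, only, none or still open, it means among the compounds named here.

Measured compounds in a functional assay on MDA-MB-231 cells (Homo sapiens) for inhibition, read by sulforhodamine B assay, tested at 10 uM; a lower number here means less inhibition, a higher number more inhibition at the concentration tested (going by the name of the read-out):

Compound 1, `CN(C)c1ccc(C2CC(c3ccc(-n4cncn4)cc3)=NN2)cc1`: in this assay compound 1 gives 7%
Compound 2, `CN1CCN(c2ccc(C3=NN(C(=O)c4ccc(F)cc4)C(c4ccc(N(C)C)cc4)C3)cc2)CC1`: in this assay compound 2 gives 3.5%

Both numbers sit close to the floor of the read-out. Within the data shown here, the gap between compound 2 and compound 1 lies within the usual scatter, so the two cannot be told apart on this read-out, and no step between them is established.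

Compound 3, `CN1CCN(c2ccc(C3=NN(S(=O)(=O)c4ccc(F)cc4)C(c4ccc(N(C)C)cc4)C3)cc2)CC1`, differs from compound 2 in one place: (4-fluorophenyl)sulfonyl in place of (4-fluorophenyl)carbonyl on an amine nitrogen in a ring. The change sits on the ring nitrogen that carries the acyl group, and the rest of the shared core is kept.

Among the measured compounds shown here, no comparable step exists among the measured compounds, so the expectation rests on the baseline alone. Because compound 2 gives 3.5% and compound 1 gives 7%, little room for a downward move remains, and no change beyond the scatter is expected in either direction. Compound 3 is expected to give about 6%, in the range 0% to 20%. The estimated step of a number 2.5 percentage points higher from compound 2 to compound 3 (within the scatter) is expected to stay within the scatter.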

Compound 3, a percentage reported as inhibition, at one concentration (the size of the read-out at that concentration, not a potency): 15.7%
Beside the measured number, compound 3's estimate is 9.7 percentage points below it, and the stated range covers the measured number.
By their numbers in this assay, from the lowest: compounds 2, 1 and 3 (each within the scatter of the next, the first and the last beyond it).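

In this assay, among these compounds, the ring nitrogen next to the ring atom that bears a 4-(dimethylamino)phenyl group responds to (4-fluorophenyl)sulfonyl in place of (4-fluorophenyl)carbonyl, with a number 12.2 percentage points higher from compound 2 to compound 3 (beyond the scatter), the only step so far that lies beyond the scatter. The position therefore has some influence on this read-out, though the step is modest and compound 3, at 15.7%, remains low on the scale. Nothing measured on these compounds bears on what lies behind the step.

Open, going by these compounds, is whether the sulfonyl link alone carries the step, which a methylsulfonyl or an unsubstituted phenylsulfonyl group on the same nitrogen would help to test. A single pair also leaves open whether the step holds when other parts of the shared core change.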